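Removing the side-chain ether oxygen in the aminopyridine series

The source may hold more compounds than are shown below. What is called first, only, known or untested is meant among the compounds shown, and "the series" means these compounds.

The shared core is kept throughout. Compound 1 `Cc1cc(N)nc(CC(C)C)c1` carries an isobutyl side chain, and in an assay on isolated protein for inhibition of Nitric oxide synthase, inducible (Homo sapiens), with a stated time of 30 min (a lower number here means a stronger inhibitor, a higher number a weaker inhibitor), compound 1 gives 193 nM. Compound 2 `COC(C)Cc1cc(C)cc(N)n1` gives only a limit in this assay, > 5000 nM. Compound 3 `Cc1cc(N)nc(CC(C)OCCF)c1` also gives only a limit in this assay, > 5000 nM. Compound 2 therefore stands at the limit alongside compound 3, and compound 1 alone yields a number. The two ether-bearing analogues sit far from compound 1: the steps are an at least 25-fold higher number from compound 1 to compound 2 (1.41 log units; beyond the scatter) and an at least 25-fold higher number from compound 1 to compound 3 (1.41 log units; beyond the scatter). Between the two ethers the step is a step that the two limits leave unreadable from compound 2 to compound 3 because both rest on (the limit of > 5000 nM in this assay, at which 2 of the 3 values shown sit).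

Compound 4 `Cc1cc(N)nc(CCCCF)c1` differs from compound 2 in that (3-fluoropropyl in place of 1-methoxyethyl on a saturated chain carbon bound to an aromatic carbon). Going by the values given here, the side chain thus loses its oxygen acceptor, which brings compound 4 nearer to compound 1 in that respect, though the chain becomes unbranched and carries a fluorine, a change no measured pair covers. Both measured steps that bear on it point the same way: adding an ether oxygen to the chain of compound 1 cost a large amount, so removing it is expected to give a lower number in this assay. Compound 4 is estimated at 800 nM, within 150 nM to 5000 nM. The expected step of an at least 6.2-fold lower number from compound 2 to compound 4 (0.79 log units; beyond the scatter) cannot be sized exactly, since compound 2 is known only as a limit.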

Compound 4, half-maximal inhibitory concentration: 170 nM
Estimate against measurement, compound 4: 4.7-fold (0.67 log units) above; low and high end bracket the measured number.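

Working notes on the side chain. In this assay, 3-fluoropropyl in place of 1-methoxyethyl on a saturated chain carbon bound to an aromatic carbon gives an at least 29-fold lower number from compound 2 to compound 4 (1.46 log units; beyond the scatter), so a chain of the same heavy-atom count, with fluorine and no ether oxygen, moves the series well away from the level of compound 2. The second new step, a 1.1-fold lower number from compound 1 to compound 4 (0.06 log units; within the scatter), shows that the unbranched fluorinated chain and the isobutyl chain of compound 1 cannot be told apart in this assay, so neither losing the branch nor adding the fluorine carries a visible cost in this pair. Across the four compounds, the two chains that keep an ether oxygen, in compound 2 and compound 3, sit at the limit, and the two without it, in compound 1 and compound 4, give readable numbers, with no compound shown going against this.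

Going by these compounds, the full size of the step to compound 4 stays open because compound 2 is known only as a limit: the limit of > 5000 nM in this assay, at which 2 of the 4 values shown sit. Also open, on these data alone, is how a plain butyl chain without fluorine, a longer chain or an amine on the side chain would compare with compound 4.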